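Efficacy notes: amide-to-benzylamine change on the shared core

This account rests on a few compounds, and the source may have more. Where it says the series, first, only, none or still open, it means among the compounds named here.

Measured so far:
- compound 1 `CC(C)c1onc(-c2c(Cl)cccc2Cl)c1COc1ccc(NC(=O)c2ccc(C(=O)O)cc2)c(C(F)(F)F)n1`: 109%
- compound 2 `CC(C)c1onc(-c2c(Cl)cccc2Cl)c1COc1ccc(N(C)C(=O)c2cccc(C(=O)O)c2)c(C(F)(F)F)n1`: 110%
- compound 3 `Cc1cc(C(F)(F)F)cc(OCc2c(-c3c(Cl)cccc3Cl)noc2C(C)C)n1`: 98%

In an assay on isolated protein for agonist activity at Bile acid receptor (Homo sapiens), read by FRET (on this read-out lower numbers stand for smaller maximal responses and higher numbers for larger maximal responses), compound 1 gives 109%, compound 2 gives 110% and compound 3 gives 98%. Compound 2 has the highest number of the three, but compound 1 sits within the scatter of it, so no order between compound 2 and compound 1 can be read. Compound 3 lies lower than compound 2 by more than the scatter. All three numbers are near the reference response.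

Compound 4 `CC(C)c1onc(-c2c(Cl)cccc2Cl)c1COc1ccc(N(C)Cc2ccc(OCC(=O)O)cc2)c(C(F)(F)F)n1` has not been measured in this assay. Relative to compound 2 the change is 4-(carboxymethoxy)benzyl in place of (3-carboxyphenyl)carbonyl on a nitrogen on an aromatic ring. Going by the values given here, no step between measured compounds separates the amide from a benzyl substituent, so the expectation rests on the narrow spread of the three measured numbers. Compound 4 is expected to give 100% in this assay, with a range from 80% to 118%. The estimate implies a step of a number 10 percentage points lower from compound 2 to compound 4 (within the scatter), expected to stay within the scatter or be slightly downward.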

Compound 4, largest response reached (reported as efficacy), in percent of the reference or control that the assay uses: 90%
For compound 4 the middle estimate is 10 percentage points above the measured one, within the range that was stated.
By their numbers in this assay, from the lowest: compounds 4 and 3 (each within the scatter of the next); then compounds 1 and 2 (each within the scatter of the next).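

In this assay, going by these compounds alone, 4-(carboxymethoxy)benzyl in place of (3-carboxyphenyl)carbonyl on a nitrogen on an aromatic ring gives a number 20 percentage points lower from compound 2 to compound 4 (beyond the scatter) and is the only step available at this place, so the maximal response does depend on the group carried on this nitrogen. The response is reduced rather than lost: compound 4 gives 90% with no carbonyl directly on that nitrogen. Nothing on hand bears on the reason for this step.

On these data alone, the change swaps the carbonyl for a benzyl link and alters the chain carrying the carboxylic acid in one move, so the share of each in the step remains open. A benzyl group bearing a plain carboxylic acid, or a phenylcarbonyl group bearing the carboxymethoxy chain, would separate the two.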